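The source may report more compounds than this note shows. Statements on the series, on what has been measured and on what is new or still open speak of the compounds shown alone.

In a functional assay on the whole organism for inhibition, with Mythimna separata as the target, with a stated time of 5 days (a higher number here means that more compound is needed for the effect, a lower number that less compound is needed), compound 1 `Cc1ccc(-c2nnc(COc3cnn(C(C)(C)C)c(=O)c3Cl)o2)cc1` gives 19900 nM. Within the data shown here, only one other compound has been measured so far: compound 2 `CC(C)(C)n1ncc(OCc2nnc(-c3c(F)c(F)c(F)c(F)c3F)o2)c(Cl)c1=O` gives 271000 nM. Compound 1 therefore has the lower of the two numbers, meaning that less of it is needed for the effect, and the gap between them lies well beyond the usual scatter.

The next compound, compound 3 `CC(C)(C)n1ncc(OCc2nnc(-c3ccc(Cl)cc3)o2)c(Cl)c1=O`, keeps the core of compound 1 and changes one group: chloro in place of methyl on an aromatic carbon. In words, this puts chloro in place of methyl on an aromatic carbon, turning 4-methylphenyl into 4-chlorophenyl.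

Among the measured compounds shown here, no measured pair in this small set shows this change on its own, so the data offer no direct guide. As only one heavy atom is exchanged for another, the expectation is a small step, with none beyond the scatter and no firm direction. The estimated change is a 1.1-fold higher number from compound 1 to compound 3 (0.04 log units; within the scatter). The distance to compound 2 at 271000 nM shows how far apart numbers in this set can lie, so the range is kept wide. For compound 3 the expected value is 22000 nM, with an estimated range from 7000 nM to 70000 nM.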

Compound 3, half-maximal effective concentration: 1900 nM
Compound 3: the middle estimate sits 12-fold (1.06 log units) above what was measured; measured number outside the range, below it.
By their numbers in this assay, from the lowest: compound 3; then compound 1; then compound 2.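

In this assay, among these compounds, the exchange of methyl for chloro gives a 10-fold lower number from compound 1 to compound 3 (1.02 log units; beyond the scatter), the first step in this set that isolates a single change. It shows that this one position, on an aromatic carbon of a six-membered aromatic ring of carbon only and para to a large group, strongly affects how much compound is needed for the effect, even though just one heavy atom is swapped and no hydrogen-bond donor, hydrogen-bond acceptor or net charge enters or leaves. No measurement here explains why chloro requires so much less compound than methyl in this setting.

Going by these compounds, with a single pair, it remains open whether other groups at this position, such as bromo, trifluoromethyl, methoxy or nitrile, would lower the number further, match chloro or lose the gain. On these data alone, it is also open whether the same exchange would produce a step of similar size if the rest of the molecule were changed, since this step has been read on the core of compound 1 alone.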